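A Chloro-to-Methyl Swap on a Cytotoxicity Plateau

This account rests on a few compounds, and the source may have more. Where it says the series, first, only, none or still open, it means among the compounds named here.

Compound 3 `O=C(NCc1ccccc1)c1c(NO)cc(-c2ccc(Cl)cc2)oc1=O` stands at the edge of what an ADME assay on Huh-7 cells (Homo sapiens) for cytotoxicity, read by a luciferase reporter and WST assay, with a stated time of 3 days (on this read-out lower numbers stand for higher toxicity in this test and higher numbers for lower toxicity in this test), can read: in this assay compound 3 gives > 20000 nM, a limit of the assay rather than a number. Compound 1 `Cc1ccc(NC(=O)c2c(NO)cc(-c3ccc(C)cc3)oc2=O)cc1` likewise returns only a limit, > 20000 nM. Compound 2 `Cc1ccc(-c2cc(NO)c(C(=O)NCCO)c(=O)o2)cc1` also returns a limit, > 20000 nM. The step from compound 1 to compound 2 is a step that the two limits leave unreadable from compound 1 to compound 2. All three values rest on (the limit of > 20000 nM in this assay, at which 3 of the 3 values shown sit). Compound 4 `Cc1ccc(-c2cc(NO)c(C(=O)NCc3ccccc3)c(=O)o2)cc1` differs from compound 3 by methyl in place of chloro on an aromatic carbon. Among the compounds with values here, no measured step bears directly on this change, and every value so far is a limit; no step beyond the scatter is expected in this assay. Compound 4 is therefore expected to give 30000 nM, within 15000 nM to 60000 nM, an expected step that the limit leaves unreadable from compound 3 to compound 4.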

Compound 4, half-maximal cytotoxic concentration: > 20000 nM
Compound 4 ended at the assay's limit; the forecaster's own chance of this, stated with the estimate: 85%; the middle value is on the limit's open side.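

No step can be read between compound 4 and compound 1, compound 2 or compound 3, since all four stand at a limit of this assay: the limit of > 20000 nM in this assay, at which 4 of the 4 values shown sit.

The compounds shown leave open whether any change to the shared core gives a readable value in this assay.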